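Benzamide series: chain extension step from compound 1

The source may hold more compounds than are shown below. What is called first, only, known or untested is meant among the compounds shown, and "the series" means these compounds.

The series shares the core seen in compound 1 `CCCCCCCCCCCCNC(=O)[C@@H](NC(=O)c1ccccc1)[C@@H](C)O`, which in a functional assay on A-431 cells (Homo sapiens) for cytotoxicity, read by MTT assay, with a stated time of 48 h (a lower number here means a stronger inhibitor, a higher number a weaker inhibitor), gives 41200 nM. Compound 2 `CCCCCCCCCCCCNC(=O)[C@@H](NC(=O)c1cccs1)[C@@H](C)O` gives 16600 nM, and compound 3 `CCCCCCCCCCCCNC(=O)[C@@H](NC(=O)c1cc2ccccc2n1C)[C@@H](C)O` gives 169000 nM. Among these three numbers compound 1 stands second highest: a 2.5-fold lower number from compound 1 to compound 2 (0.39 log units; beyond the scatter), while a 4.1-fold higher number from compound 1 to compound 3 (0.61 log units; beyond the scatter). Between the other two, a 10-fold higher number from compound 2 to compound 3 (1.01 log units; beyond the scatter). Every measured step exchanges the group on the carbonyl carbon and leaves the chain untouched.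

Compound 4 `CCCCCCCCCCCCCCCCCCNC(=O)[C@@H](NC(=O)c1ccccc1)[C@@H](C)O` differs from compound 1 in one place: hexyl in place of hydrogen on a saturated chain carbon, ten or more bonds along the chain from an amide-type nitrogen. Going by the values given here, no measured step touches the chain, so none bears directly on this change; the measured steps show only that the aryl group moves the number by modest to large amounts, which says nothing about chain length. For compound 4 the step expected is therefore a 1.2-fold lower number from compound 1 to compound 4 (0.07 log units; within the scatter), held within the usual scatter and given a wide range for want of any comparable step. Compound 4 is expected to give 35000 nM in this assay, with a range from 10000 nM to 120000 nM.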

Compound 4, half-maximal inhibitory concentration: 113000 nM
Estimate against measurement, compound 4: 3.2-fold (0.51 log units) below; the measured number falls inside the stated range.
By their numbers in this assay, from the lowest: compound 2; then compound 1; then compounds 4 and 3 (each within the scatter of the next).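

Going by these compounds alone, compound 4 gives the first reading on the chain itself: in this assay, hexyl in place of hydrogen on a saturated chain carbon, ten or more bonds along the chain from an amide-type nitrogen, gives a 2.7-fold higher number from compound 1 to compound 4 (0.44 log units; beyond the scatter), so a higher number goes with the longer chain in this benzamide pair. The position is therefore not silent, and a change far along the chain moves the number beyond the scatter. With one chain pair, this is a single step and not a trend in chain length.

As far as these compounds go, it remains open whether a shorter chain, such as octyl, would give a lower number, and what a terminal amine or carboxylic acid on the chain would do. From the compounds shown here alone, whether the same extension holds for compound 2 is also open. Nothing on hand accounts for the shift.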